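A second nitro group on the aryl ring of compound 1

This account rests on a few compounds, and the source may have more. Where it says the series, first, only, none or still open, it means among the compounds named here.

Compound 1 `CCOC(=O)c1c(C)[nH]c(=O)c(C#N)c1-c1ccc([N+](=O)[O-])cc1` gives 7000 nM in a functional assay on aorta (Rattus norvegicus) for inhibition (a higher number here means that more compound is needed for the effect, a lower number that less compound is needed), the lowest of the three numbers measured. Going by the values given here, compound 2 `CCOC(=O)c1c(C)[nH]c(=O)c(C#N)c1-c1ccco1` gives 22000 nM and compound 3 `CCOC(=O)c1c(C)[nH]c(=O)c(C#N)c1-c1cccc(Cl)c1` gives 85000 nM; the only measured single step, a 3.9-fold higher number from compound 2 to compound 3 (0.59 log units; beyond the scatter), concerns a swap of the whole aryl ring and does not bear directly on the change to compound 4 `CCOC(=O)c1c(C)[nH]c(=O)c(C#N)c1-c1ccc([N+](=O)[O-])cc1[N+](=O)[O-]`, which is nitro in place of hydrogen on an aromatic carbon. Among the compounds with values here, no measured pair shows the effect of adding a nitro group to an aryl ring on the shared core, so the direction of this step cannot be read from the data. Compound 4 is therefore expected to give an estimated 8000 nM (range 2500 nM to 25000 nM). The expected step of a 1.1-fold higher number from compound 1 to compound 4 (0.06 log units; within the scatter) is taken to lie within the scatter.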

Compound 4, half-maximal effective concentration: 4400 nM
Compound 4: middle estimate off by 1.8-fold (0.26 log units), on the high side; the measured number falls inside the stated range.
By their numbers in this assay, from the lowest: compounds 4 and 1 (each within the scatter of the next); then compound 2; then compound 3.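

In this assay, nitro in place of hydrogen on an aromatic carbon, ortho to a large group and meta to a nitro group, gives a step within the scatter (a 1.6-fold lower number from compound 1 to compound 4 (0.20 log units; within the scatter)). Going by these compounds alone, this is the first measured step at a single position with the aryl ring itself kept, and this position accepts a second nitro group with compound 4 level with compound 1. Within the data shown here, no measurement on these compounds bears on this result.

Open: whether an amine or a carboxylic acid at this position would stay level with compound 1, and whether adding nitro to the 3-chlorophenyl ring of compound 3 gives a similar step.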